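Methoxyphenyl for Methylphenyl on the Triazole Nitrogen

The source may report more compounds than this note shows. Statements on the series, on what has been measured and on what is new or still open speak of the compounds shown alone.

Measured compounds:
compound 1, `Cc1ccc(-n2nncc2CN2C(=O)C3(C(C#N)=C(N)Oc4c3c3nc5ccccc5nc3c3ccccc43)c3ccccc32)cc1Cl`: > 50000 nM
compound 2, `Cc1ccccc1-n1nncc1CN1C(=O)C2(C(C#N)=C(N)Oc3c(N)cc4nc5ccccc5nc4c32)c2ccccc21`: 31700 nM

For the measured compounds named here, in a functional assay on A549 cells (Homo sapiens) for antiproliferative activity, read by MTT assay, with a stated time of 48 h (on this read-out higher numbers stand for weaker inhibition and lower numbers for stronger inhibition), compound 2 gives 31700 nM, the only number among the two compounds measured. Compound 1 reaches only a limit of this assay, > 50000 nM; the limit of > 50000 nM in this assay, at which 1 of the 2 values shown sits, tells where it sits.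

Compound 3, `COc1ccc(-n2nncc2CN2C(=O)C3(C(C#N)=C(N)Oc4c(N)cc5nc6ccccc6nc5c43)c3ccccc32)cc1`, differs from compound 2 by 4-methoxyphenyl in place of 2-methylphenyl on an aromatic nitrogen. Going by the values given here, no step between measured compounds is known for a change of this kind, so the step is expected to be small, a 1.1-fold lower number from compound 2 to compound 3 (0.05 log units; within the scatter), and not beyond the usual scatter in either direction. Compound 3 is therefore estimated at 28000 nM in this assay, with a range from 9000 nM to 60000 nM.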

Compound 3, half-maximal inhibitory concentration: > 50000 nM
Compound 3 gave a limit, no number; the forecaster's own chance of this, stated with the estimate: 35%; at least 1.7-fold (0.25 log units) between middle value and limit.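

In this assay compound 3 gives > 50000 nM, which is a limit and not a number. From the compounds shown here alone, at this aromatic nitrogen, 4-methoxyphenyl in place of 2-methylphenyl gives an at least 1.5-fold higher number from compound 2 to compound 3 (0.19 log units; that floor lies within the scatter), so the change brings no gain, although the size of the step remains unknown and its floor does not separate the two compounds. Only one compound in the set now keeps a number: the limit of > 50000 nM in this assay, at which 2 of the 3 values shown sit.

Going by these compounds, it remains open whether a 4-aminophenyl or a benzyl group on this nitrogen would give a number in this assay. On these data alone, how far compound 3 actually lies past its limit also remains open.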